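A Thioether Replacement on a Nucleoside Transporter Inhibitor

The compounds below may be only part of what the source reports. "The series", "measured", "known", "first", "only" and "open" are said of these compounds alone.

Measured so far:
compound 1, `Nc1ncnc2c1ncn2[C@@H]1O[C@H](COCCOCCNc2ncnc3c2ncn3[C@@H]2O[C@H](CO)[C@@H](O)[C@H]2O)[C@@H](O)[C@H]1O`, 912000 nM
compound 2, `OC[C@H]1O[C@@H](n2cnc3c(NCc4ccco4)ncnc32)[C@H](O)[C@@H]1O`, 36300 nM
compound 3, `CC(C)Sc1nc(N)nc2c1ncn2[C@@H]1O[C@H](CO)[C@@H](O)[C@H]1O`, 191000 nM

In an assay on isolated protein for binding affinity to Equilibrative nucleoside transporter 1 (Homo sapiens) (a lower number here means a stronger inhibitor, a higher number a weaker inhibitor), compound 2 gives 36300 nM, the lowest of the three numbers. Its nearest neighbour is compound 3, whose number is higher by a margin beyond the usual scatter; compound 1 lies furthest away, also well beyond the scatter. Compound 2 is thus the strongest inhibitor among the three measured compounds.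

Compound 4, `OC[C@H]1O[C@@H](n2cnc3c(CSc4ccccc4F)ncnc32)[C@H](O)[C@@H]1O`, has not yet been measured in this assay. It differs from compound 2 in one place: ((2-fluorophenyl)sulfanyl)methyl in place of ((furan-2-yl)methyl)amino on an aromatic carbon. Within the data shown here, no measured pair in this set shows the effect of such a change, so the expectation rests on compound 2 alone. A step of modest size toward a lower number is expected, a 3.0-fold lower number from compound 2 to compound 4 (0.48 log units; beyond the scatter), though it may not exceed the scatter. Compound 4 is estimated at 12000 nM, within a range from 1500 nM to 90000 nM.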

Compound 4, half-maximal inhibitory concentration: 355 nM
Compound 4: middle estimate off by 34-fold (1.53 log units), on the high side; the whole stated range lies above it.
By their numbers in this assay, from the lowest: compound 4; then compound 2; then compound 3; then compound 1.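

The change at this aromatic carbon, next to the ring nitrogen, gives a large gain in this assay, with a 100-fold lower number from compound 2 to compound 4 (2.01 log units; beyond the scatter), so this place on the shared core can strongly shift the number. The leaving ((furan-2-yl)methyl)amino group has 1 hydrogen-bond donor and the entering ((2-fluorophenyl)sulfanyl)methyl group has 0, so that donor is not needed for a number as low as that of compound 4. Nothing given here accounts for the size of this step.

The step replaces the link, the ring and the fluorine together, and the compounds shown do not assign it to any one of them. From the compounds shown here alone, whether a (phenylsulfanyl)methyl group without the fluorine, or a (2-fluorobenzyl)amino group that keeps the nitrogen, would give a similarly low number remains open.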